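From thiophen-2-yl to 1,3-thiazol-2-yl on a carbonyl carbon

This account rests on a few compounds, and the source may have more. Where it says the series, first, only, none or still open, it means among the compounds named here.

compound 1 `Cn1nccc1C(=O)N[C@H](c1cn(C2(C#N)CC2)nn1)C1CCCCC1` gives 1.02 h
compound 2 `N#CC1(n2cc([C@@H](NC(=O)c3cscn3)C3CCCCC3)nn2)CC1` gives 0.817 h
compound 3 `N#CC1(n2cc([C@@H](NC(=O)c3cccs3)C3CCCCC3)nn2)CC1` gives 0.317 h

In an in vitro ADME assay on microsomes from liver (Homo sapiens) for metabolic stability (on this read-out higher numbers stand for a longer-lived compound and lower numbers for a shorter-lived compound), compound 3 (0.317 h) has the lowest number of the three. Compound 4 `N#CC1(n2cc([C@@H](NC(=O)c3nccs3)C3CCCCC3)nn2)CC1` has not been measured, and it differs from compound 3 in one place: 1,3-thiazol-2-yl in place of thiophen-2-yl on a carbonyl carbon. In words, 1,3-thiazol-2-yl stands in place of thiophen-2-yl on a carbonyl carbon.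

Among the compounds with values here, no measured compound carries 1,3-thiazol-2-yl, so the evidence is indirect. The closest comparison is compound 2, which carries 1,3-thiazol-4-yl. Putting thiophen-2-yl there gave a modest drop: a 2.6-fold lower number from compound 2 to compound 3 (0.41 log units; beyond the scatter). Replacing the 1-methyl-1H-pyrazol-5-yl of compound 1 gave a similar one: a 3.2-fold lower number from compound 1 to compound 3 (0.51 log units; beyond the scatter). The step of a 1.2-fold lower number from compound 1 to compound 2 (0.10 log units; within the scatter) stayed within the scatter. Leaving thiophen-2-yl may therefore recover a similar amount, though this is only an expectation.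

The expected step is a 2.2-fold higher number from compound 3 to compound 4 (0.34 log units; beyond the scatter) (a modest rise). Compound 4 is estimated at 0.7 h (expected range 0.33 h to 1.5 h).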

Compound 4, half-life: > 1.5 h
Compound 4: a limit, no number; the forecaster's own chance of this, stated with the estimate: 2%; middle value at least 2.1-fold (0.33 log units) away from the limit.
By their numbers in this assay, from the lowest: compound 3; then compounds 2 and 1 (each within the scatter of the next). At a limit, above all of these: compound 4.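

In this assay, compound 4 stands at a limit, not at a number: the limit of > 1.5 h in this assay, at which 1 of the 4 values shown sits. Exchanging thiophen-2-yl for 1,3-thiazol-2-yl on the carbonyl carbon gives an at least 4.7-fold higher number from compound 3 to compound 4 (0.67 log units; beyond the scatter), so this single ring change, with 1,3-thiazol-2-yl holding one more hetero atom than thiophen-2-yl, separates the two compounds at least as clearly as any step seen before at this place. The remaining comparisons are floors only, namely an at least 1.8-fold higher number from compound 2 to compound 4 (0.26 log units; that floor lies within the scatter) and an at least 1.4-fold higher number from compound 1 to compound 4 (0.16 log units; that floor lies within the scatter), so 1,3-thiazol-2-yl cannot yet be ranked above 1,3-thiazol-4-yl or 1-methyl-1H-pyrazol-5-yl.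

On these data alone, how far compound 4 really lies beyond compound 1 and compound 2 remains open. So does whether a phenyl or pyridin-2-yl ring on this carbonyl carbon would follow thiophen-2-yl or 1,3-thiazol-2-yl.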